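Amide variation on the shared core: pyridinyl in place of aminophenyl

This account rests on a few compounds, and the source may have more. Where it says the series, first, only, none or still open, it means among the compounds named here.

Measured so far:
compound 1 `O=C(Nc1nnc(-c2ccc3c(c2)OCCO3)s1)c1ccccc1` gives 46.2 ug/mL in a functional assay on BGC-823 cells (Homo sapiens) for antiproliferative activity, read by MTT assay, with a stated time of 48 h; on this read-out lower numbers stand for an effect already at smaller amounts and higher numbers for an effect only at larger amounts of compound
compound 2 `Nc1ccc(C(=O)Nc2nnc(-c3ccc4c(c3)OCCO4)s2)cc1` reaches only the limit > 100 ug/mL
compound 3 `O=C(Nc1nnc(-c2ccc3c(c2)OCCO3)s1)c1ccc(Cl)nc1` reaches only the limit > 100 ug/mL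

Within the data shown here, compound 1 is the only member with a number rather than a limit. The step of an at least 2.1-fold higher number from compound 1 to compound 2 (0.33 log units; beyond the scatter) and the step of an at least 2.1-fold higher number from compound 1 to compound 3 (0.33 log units; beyond the scatter) both run from that number up to the limit, and the step that the two limits leave unreadable from compound 2 to compound 3 cannot be sized, as both ends are limits. Compound 2 therefore stands at the top of the shown range, defined only by the limit of > 100 ug/mL in this assay, at which 2 of the 3 values shown sit.

Compound 4 `Cc1ccc(C(=O)Nc2nnc(-c3ccc4c(c3)OCCO4)s2)cn1` differs from compound 2 by 6-methylpyridin-3-yl in place of 4-aminophenyl on a carbonyl carbon. The step from compound 1 to compound 3, which also brought in a pyridin-3-yl group on the carbonyl carbon, landed at the limit, and the step from compound 1 to compound 2 did the same. Nothing in the series points back toward the number of compound 1.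

Compound 4 is therefore expected to sit near or at the limit as well, with 120 ug/mL and a range from 45 ug/mL to 300 ug/mL. The corresponding expected step is a step that the limit leaves unreadable from compound 2 to compound 4, which is estimated as no change beyond the scatter from a compound already at the limit.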

Compound 4, half-maximal effective concentration: > 100 ug/mL
Compound 4: a limit, no number; the forecaster's own chance of this, stated with the estimate: 65%; the middle value lies beyond the limit too.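

In this assay, compound 4 also gives a limit and not a number, so methyl in place of chloro on the pyridine's aromatic carbon does not bring a readable value back. Set against the phenyl amide, the result is an at least 2.1-fold higher number from compound 1 to compound 4 (0.33 log units; beyond the scatter), which adds a second substituted pyridin-3-yl group to the move away from the number of compound 1, and this time the entering group has no hydrogen-bond donor, whereas the 4-aminophenyl group it replaces in compound 2 has one. The steps among compound 2, compound 3 and compound 4 cannot be read, as both ends of each are limits, so on the carbonyl carbon the series now rests on a single number, that of compound 1, and on one shared limit: the limit of > 100 ug/mL in this assay, at which 3 of the 4 values shown sit.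

The compounds shown leave open how far beyond the limit compound 2, compound 3 and compound 4 lie, and whether they differ from one another at all. They also leave open whether an unsubstituted pyridin-3-yl group, or a fluoro or methoxy group on the phenyl ring, would stay near the number of compound 1.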